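The source may hold more compounds than are shown below. What is called first, only, known or untested is meant among the compounds shown, and "the series" means these compounds.

Measured so far:
compound 1 `CC(=O)NCc1cccc(Cn2nc(NS(=O)(=O)c3ccc(Cl)s3)c3c(C#N)cccc32)c1`, 316 nM
compound 2 `CC(=O)NCc1cccc(Cn2nc(NS(=O)(=O)c3ccc(Cl)s3)c3c(CO)cccc32)c1`, 6.31 nM
compound 3 `COc1cccc2c1c(NS(=O)(=O)c1ccc(Cl)s1)nn2Cc1cccc(CNC(=O)C2CCO2)c1`, 31.6 nM

In a functional assay on CHO cells for antagonist activity at C-C chemokine receptor type 4 (Homo sapiens), read by GTPgammaS binding (a lower number here means a stronger inhibitor, a higher number a weaker inhibitor), compound 3 gives the second highest of the three numbers; compound 2 gives a lower value and compound 1 a higher one, both gaps beyond the scatter. For the measured compounds named here, the only single-point step among the measured compounds is a 50-fold lower number from compound 1 to compound 2 (1.70 log units; beyond the scatter), which changes the substituent on the shared core, not the amide end of the benzyl side chain.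

Compound 4 `COc1cccc2c1c(NS(=O)(=O)c1ccc(Cl)s1)nn2Cc1cccc(CNC(=O)C(C)(C)N)c1` differs from compound 3 only at the far amide: 1-amino-1-methylethyl in place of oxetan-2-yl on a carbonyl carbon. Going by the values given here, no measured step touches this position, so the change is untested in this set. Without a bearing step, compound 4 is expected to stay near compound 3, with a step of no change at the digits printed from compound 3 to compound 4 (within the scatter) in this assay. Compound 4 is therefore estimated at 31.6 nM, in the range 10 nM to 100 nM.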

Compound 4, half-maximal inhibitory concentration in the C-C chemokine receptor type 4 assay: 15.9 nM
Compound 4: the middle estimate sits 2.0-fold (0.30 log units) above what was measured; low and high end bracket the measured number.
By their numbers in the C-C chemokine receptor type 4 assay, from the lowest: compound 2; then compounds 4 and 3 (each within the scatter of the next); then compound 1.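

For the compounds shown here, in the C-C chemokine receptor type 4 assay, the first step at the far amide, on a carbonyl carbon, gives a 2.0-fold lower number from compound 3 to compound 4 (0.30 log units; within the scatter), so this assay does not tell the ring-bearing oxetan-2-yl from the open-chain 1-amino-1-methylethyl. In a physicochemical assay for solubility, read by chemiluminescence, measured as kinetic solubility (on this read-out lower numbers stand for lower solubility and higher numbers for higher solubility), the same change gives an at least 1.4-fold higher number from compound 3 to compound 4 (0.16 log units; that floor lies within the scatter). In the physicochemical assay, compound 3 gives 124 ug/mL. In the physicochemical assay, compound 4 gives >= 180 ug/mL, which is a limit of that assay, not a number: the limit of >= 180 ug/mL in the physicochemical assay, at which 1 of the 2 values shown sits.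

Still open, on these data alone, is how a carboxylic acid or a longer chain on this carbonyl carbon would read. Also open, as far as these compounds go, is whether the step holds with hydroxymethyl on the shared core in place of methoxy.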